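This account rests on a few compounds, and the source may have more. Where it says the series, first, only, none or still open, it means among the compounds named here.

Of the compounds shown here, three have been measured in a functional assay on DU-145 cells (Homo sapiens) for cytotoxicity, read by sulforhodamine B assay, with a stated time of 48 h, tested at 0.1 uM; a higher number here means a weaker effect of the compound at the concentration tested, a lower number a stronger effect: compound 1 `COc1ccc(-c2cc(/C=C/C(=O)c3ccc(N)cc3)[nH]n2)cc1`, compound 2 `COc1cc(-c2cc(/C=C/C(=O)c3ccc(N)cc3)[nH]n2)cc(OC)c1OC` and compound 3 `COc1ccc(C(=O)/C=C/c2cc(-c3cc(OC)c(OC)c(OC)c3)n[nH]2)cc1`. Compound 1 gives 100%, compound 2 gives 104% and compound 3 gives 101%. Compound 2 holds the top number of the three, but its distances to compound 3 and to compound 1 are both within the scatter, so nothing separates the three. For the measured compounds named here, the one recorded step, a number 3 percentage points lower from compound 2 to compound 3 (within the scatter), concerns a different position and shows that methoxy in place of amino on an aromatic carbon left the read-out where it was.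

Compound 4 `COc1ccc(-c2cc(/C=C/C(=O)c3ccc(N)cc3)[nH]n2)cc1OC` is the next compound for this assay. It differs from compound 2 by hydrogen in place of methoxy on an aromatic carbon. Going by the values given here, no measured step removes a methoxy from this ring; the only guide is that no change has moved the read-out beyond the scatter. The step from compound 2 to compound 4 is therefore expected to be none beyond the scatter, a number 3 percentage points lower from compound 2 to compound 4 (within the scatter). For compound 4 the estimate is 101%, expected to fall between 90% and 112%.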

Compound 4, a percentage reported as activity, at one concentration (the size of the read-out at that concentration, not a potency): 110%
Beside the measured number, compound 4's estimate is 9 percentage points below it, within the range that was stated.
By their numbers in this assay, from the lowest: compounds 1, 3, 2 and 4 (each within the scatter of the next).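

In this assay the methoxy-bearing ring now has steps of its own: hydrogen in place of methoxy gives a number 6 percentage points higher from compound 2 to compound 4 (within the scatter), and methoxy in place of hydrogen gives a number 10 percentage points higher from compound 1 to compound 4 (within the scatter). Across compounds 1, 4 and 2, adding or removing a methoxy on this ring therefore leaves the read-out within the scatter at the single concentration tested, as the change from amino to methoxy did on the other ring. Nothing available bears on why this read-out stays put.

Open, going by these compounds, is whether a group other than methoxy at this place, such as a hydroxyl, a chlorine or an ethoxy, would move the read-out beyond the scatter. Also open, on these data alone, is whether these compounds would differ in the size of their effect at any other concentration, as only one concentration was tested.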